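Purine glycinamide series: notes toward compound 4

The compounds below may be only part of what the source reports. "The series", "measured", "known", "first", "only" and "open" are said of these compounds alone.

Three compounds of the series have numbers in a functional assay on the whole organism (Tail, strain ICR) with Mus musculus as the target, in the tail flick test, with a stated time of 120 min, at a dose of 25 umol/kg by the oral route; on this read-out lower numbers stand for a weaker effect and higher numbers for a stronger effect at the one dose given. Compound 1 `O=C(CN(c1nc(Cl)nc2[nH]cnc12)C1CC1)N[C@@H](CCC(=O)OCc1ccccc1)C(=O)OCc1ccccc1` gives 45.9% and stands highest of the three, with both gaps to the other compounds beyond the usual scatter. Compound 2 `O=C(CN(c1ncnc2c1ncn2C1CCCCO1)C1CC1)N[C@@H](CO)C(=O)OCc1ccccc1`, on a different core, gives 29.2% in this assay. Compound 3 `CSCC[C@H](NC(=O)CN(c1nc(Cl)nc2[nH]cnc12)C1CC1)C(=O)O`, which carries a carboxylic acid where the others carry a benzyloxycarbonyl group, gives 5.67% in this assay. No pair among these three differs in one place only, so no single step has been isolated so far.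

Compound 4 `NC(=O)C[C@H](NC(=O)CN(c1nc(Cl)nc2[nH]cnc12)C1CC1)C(=O)OCc1ccccc1` is the next member to be measured. It differs from compound 1 as follows: carbamoyl in place of (benzyloxycarbonyl)methyl on a saturated chain carbon, two bonds along the chain from an amide-type nitrogen and a carbonyl carbon. The benzyloxycarbonyl group on the amino acid end is kept; the side chain is shortened and its outer group changes from an ester to one carrying a donor. Nothing measured shows this exchange directly. For the measured compounds named here, since compound 3, with 5.67%, is the one member without a benzyloxycarbonyl group and compound 4 retains one, a moderate downward step is expected rather than a collapse: a number 15.9 percentage points lower from compound 1 to compound 4 (beyond the scatter). Compound 4 is therefore estimated to give 30% in this assay, with a range from 12% to 48%.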

Compound 4, a percentage reported as activity, at one dose (the size of the read-out at that dose, not a potency): 15.1%
Estimate against measurement, compound 4: 14.9 percentage points above; low and high end bracket the measured number.
By their numbers in this assay, from the lowest: compounds 3 and 4 (each within the scatter of the next); then compound 2; then compound 1.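

In this assay, for the compounds shown here, the exchange of (benzyloxycarbonyl)methyl for carbamoyl on a saturated chain carbon, two bonds along the chain from an amide-type nitrogen and a carbonyl carbon, gives a number 30.8 percentage points lower from compound 1 to compound 4 (beyond the scatter) and is the first single-place step. With the core and the benzyloxycarbonyl group on the amino acid end kept, this side-chain position is clearly not indifferent at the one dose given, and keeping that benzyloxycarbonyl group does not by itself preserve the number of compound 1. The exchange alters the chain, removes the six-membered aromatic ring of carbon only and adds a hydrogen-bond donor all at once, and no measurement here bears on which of these changes accounts for the step.

The compounds shown do not separate chain length from the outer group, and a 2-carbamoylethyl side chain or a benzyloxycarbonyl group placed directly on the shorter chain would address that question. From the compounds shown here alone, it also remains open how an amine or a carboxylic acid at the end of this side chain would read with the rest of compound 4 unchanged.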